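A few compounds are considered here, and "the series" means these few. Any claim that something is new, unique, unknown or untested is made for them only; others in the source may bear on it.

Compound 1 `COc1ccc(/C=C/c2cc(OC)cc(OC)c2/C=C/C(=O)c2cc3ccc(Br)cc3oc2=O)cc1` gives 55300 nM in an assay on isolated protein for inhibition of Amine oxidase [flavin-containing] B (Homo sapiens), read by fluorescence, with a stated time of 15 min; a higher number here means a weaker inhibitor, a lower number a stronger inhibitor.
Compound 2 `COc1ccc(/C=C/c2cc(OC)cc(OC)c2/C=C/C(=O)c2cc3ccc(Cl)cc3oc2=O)cc1` gives 7360 nM in this assay.

Compound 2 holds the lowest of the two numbers; its nearest neighbour is compound 1, and that step is a 7.5-fold lower number from compound 1 to compound 2 (0.88 log units; beyond the scatter), chloro in place of bromo. Compound 3 `COc1ccc(/C=C/c2cc(OC)cc(OC)c2/C=C/C(=O)c2cc3cc(C)ccc3oc2=O)cc1` differs from compound 2 by a group of 12 heavy atoms (10 carbon, 2 oxygen; one six-membered aromatic ring of carbon only, one six-membered aromatic ring with 1 hetero atom) in place of a group of 12 heavy atoms (9 carbon, 2 oxygen, 1 chlorine; one six-membered aromatic ring of carbon only, one six-membered aromatic ring with 1 hetero atom), on a carbonyl carbon. Within the data shown here, no measured step covers this exchange; the only step known swaps one halogen for another and is modest. The expected change is therefore a 1.6-fold higher number from compound 2 to compound 3 (0.21 log units; within the scatter), small and of uncertain direction. Compound 3 is estimated at 12000 nM, within 3000 nM to 45000 nM.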

Compound 3, half-maximal inhibitory concentration: 5090 nM
The estimate for compound 3 lay 2.4-fold (0.37 log units) above the measured number; the measured number falls inside the stated range.
By their numbers in this assay, from the lowest: compounds 3 and 2 (each within the scatter of the next); then compound 1.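

At the carbonyl carbon, the group of 10 carbon and 2 oxygen, which carries no halogen, is not told apart from the chlorine-bearing group (a 1.4-fold lower number from compound 2 to compound 3 (0.16 log units; within the scatter)), yet it stands clearly apart from the bromine-bearing group (an 11-fold lower number from compound 1 to compound 3 (1.04 log units; beyond the scatter)). In this assay, a halogen on this group is therefore not needed for the lower numbers, and among these three compounds only the bromine-bearing compound 1 stands apart. Nothing available explains this difference.

On these data alone, what an amine, a nitrile or a carboxylic acid would do in place of the halogen stays open. So does whether a longer chain would keep the number of compound 3.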